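The source may hold more compounds than are shown below. What is called first, only, known or untested is meant among the compounds shown, and "the series" means these compounds.

Measured so far:
- compound 1 `C=CCOc1c(C)c(C)c2c(c1C)CCC(C)(COc1ccc(/C=C3\SC(=O)NC3=O)cc1)O2`: 42%
- compound 2 `C=CCOc1c(C)c(C)c2c(c1C)CCC(C)(COc1ccc(/C=C3\SC(=O)NC3=O)cc1OC)O2`: 5%
- compound 3 `CC(C)=CCOc1c(C)c(C)c2c(c1C)CCC(C)(COc1ccc(/C=C3\SC(=O)NC3=O)cc1F)O2`: 87%

All three share one core and were tested in a functional assay on MCF7 cells (Homo sapiens), tested at 5 uM; a lower number here means a stronger effect, a higher number a weaker effect of the compound at the concentration tested. Compound 3 stands at the highest of the three numbers, meaning the weakest effect; its gap to compound 1 and its larger gap to compound 2 both lie beyond the scatter.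

Compound 4 `CC(C)=CCOc1c(C)c(C)c2c(c1C)CCC(C)(COc1ccc(/C=C3\SC(=O)NC3=O)cc1Br)O2` differs from compound 3 in one place: bromo in place of fluoro on an aromatic carbon. One small group of a single heavy atom gives way to another of a single heavy atom, on the same ring that carries the large group and the group of 8 heavy atoms.

Among the compounds with values here, only one measured step touches that ring: a number 37 percentage points lower from compound 1 to compound 2 (beyond the scatter), a methoxy entering where hydrogen stood. Within the data shown here, it shows that a single change on this ring can move the number a great deal, but no measured step swaps one small group for another there, so it gives no direction for the present change. The expectation is therefore a modest step, a number 12 percentage points lower from compound 3 to compound 4 (beyond the scatter), most likely a small lowering, with wide uncertainty. Compound 4 is expected to give about 75%, within a range from 45% to 100%.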

Compound 4, a percentage reported as activity, at one concentration (the size of the read-out at that concentration, not a potency): 84%
Beside the measured number, compound 4's estimate is 9 percentage points below it; the range from low to high includes it.
By their numbers in this assay, from the lowest: compound 2; then compound 1; then compounds 4 and 3 (each within the scatter of the next).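

Putting bromo in place of fluoro, on the aromatic carbon ortho to a large group and meta to a group of 8 heavy atoms, gives a number 3 percentage points lower from compound 3 to compound 4 (within the scatter) in this assay, so this pair cannot be told apart. Within the data shown here, this is the first measured exchange of one single-atom group for another at this position, and it shows that such an exchange need not move the number, whereas methoxy in place of hydrogen gave a number 37 percentage points lower from compound 1 to compound 2 (beyond the scatter), a step measured on compounds that also differ from compound 3 and compound 4 elsewhere in their structures. Nothing available here bears on why compound 3 and compound 4 read alike.

The compounds shown leave open whether methoxy at this position would give a similarly large step when the rest of the molecule is that of compound 4. They also leave open how a group of a different kind at this position, such as an amine or a carboxylic acid, would read in this assay.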